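Replacing 2-methylphenyl with 4-chlorophenyl in compound 3

The source may report more compounds than this note shows. Statements on the series, on what has been measured and on what is new or still open speak of the compounds shown alone.

Three related compounds already have numbers in a functional assay on MCF7 cells (Homo sapiens) for cytotoxicity, read by ELISA, with a stated time of 4 days; on this read-out lower numbers stand for stronger inhibition and higher numbers for weaker inhibition. Compound 1 `Cc1ccsc1-c1cc(-c2ccco2)cc(-c2ccc(Cl)cc2)n1` gives 890 nM, compound 2 `Cc1ccc(-c2cc(-c3ccoc3)cc(-c3ccc(Cl)s3)n2)o1` gives 1900 nM, and compound 3 `Cc1ccccc1-c1cc(-c2ccoc2)cc(-c2ccc(Cl)s2)n1` gives 1430 nM. Compound 3 therefore lies within the usual scatter of both of the others.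

Compound 4 `Clc1ccc(-c2cc(-c3ccoc3)cc(-c3ccc(Cl)s3)n2)cc1` differs from compound 3 in one place, with 4-chlorophenyl in place of 2-methylphenyl on an aromatic carbon next to the ring nitrogen (4-chlorophenyl in place of 2-methylphenyl on an aromatic carbon).

Among the measured compounds shown here, the closest evidence is the one measured step at this carbon, a 1.3-fold lower number from compound 2 to compound 3 (0.12 log units; within the scatter), which exchanged 5-methylfuran-2-yl for 2-methylphenyl. For the measured compounds named here, that step is small, but it is only a single example. Compound 1 also carries 4-chlorophenyl and gives 890 nM, although its other groups differ, so it offers only a loose guide.

The expected change is therefore no larger than the scatter, with a 1.3-fold lower number from compound 3 to compound 4 (0.11 log units; within the scatter) as the estimated step. The estimated value for compound 4 is 1100 nM, with an expected range of 450 nM to 2600 nM.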

Compound 4, half-maximal inhibitory concentration: 2600 nM
Estimate against measurement, compound 4: 2.4-fold (0.37 log units) below, within the range that was stated.
By their numbers in this assay, from the lowest: compounds 1, 3, 2 and 4 (each within the scatter of the next, the first and the last beyond it).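

In this assay, three groups have now been read on this aromatic carbon next to the ring nitrogen, with the rest of the molecule unchanged: 5-methylfuran-2-yl, 2-methylphenyl and 4-chlorophenyl. The new comparisons are a 1.8-fold higher number from compound 3 to compound 4 (0.26 log units; within the scatter) and a 1.4-fold higher number from compound 2 to compound 4 (0.14 log units; within the scatter), so neither exchange for 4-chlorophenyl moves the number beyond the scatter, and a furan and two differently substituted phenyl rings are not told apart at this carbon. No measurement here bears on why these numbers fall as they do.

Going by these compounds, whether a group of another kind at this carbon, such as an amine or a carboxylic acid, would give a clearly different number remains open. Also open, on these data alone, are the separate contributions of methyl and chlorine, since 2-methylphenyl and 4-chlorophenyl differ in both the substituent and its place on the phenyl ring, and an unsubstituted phenyl or a 4-methylphenyl would help separate them.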